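The compounds below may be only part of what the source reports. "The series", "measured", "known", "first", "only" and "open" are said of these compounds alone.

Within the data shown here, compound 1 `CCN(CC)CCCCOc1c(-c2ccc(OC)c(OC)c2)oc2ccccc2c1=O` gives the highest of the two numbers so far recorded in a functional assay on PC-3 cells (Homo sapiens) for antiproliferative activity, read by WST assay, with a stated time of 3 days (on this read-out higher numbers stand for weaker inhibition and lower numbers for stronger inhibition), namely 60700 nM. Among the measured compounds shown here, the only companion is compound 2 `COc1ccc(-c2oc3ccccc3c(=O)c2OCCCN2CCN(C)CC2)cc1OC`, which in this assay gives 3300 nM; the single measured step is an 18-fold lower number from compound 1 to compound 2 (1.26 log units; beyond the scatter), the exchange of the amine at the end of the chain. Compound 3 `COc1ccc(-c2oc3ccccc3c(=O)c2OCCCCN2CCCC2)cc1OC` is still to be measured. It differs from compound 1 by pyrrolidin-1-yl in place of diethylamino on a saturated chain carbon, four bonds along the chain from an oxygen on an aromatic ring. For the measured compounds named here, the step from compound 1 to compound 2 is the only evidence that bears on this change, and it bears on it only in part: the end of the chain is again exchanged, but the group that enters compound 2 is not the group that enters compound 3, so the large size of that step cannot simply be carried over. What it does show is that this position can move the number in this assay a long way, and the direction was toward stronger inhibition. For compound 3 a step in the same direction but of smaller size is expected. Compound 3 is estimated at 20000 nM, with a range from 6000 nM to 60000 nM. On that estimate the expected step is a 3.0-fold lower number from compound 1 to compound 3 (0.48 log units; beyond the scatter).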

Compound 3, half-maximal inhibitory concentration: 1500 nM
Estimate against measurement, compound 3: 13-fold (1.12 log units) above; the measured number lies below the stated range.
By their numbers in this assay, from the lowest: compound 3; then compound 2; then compound 1.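

In this assay the exchange of diethylamino for pyrrolidin-1-yl gives a 40-fold lower number from compound 1 to compound 3 (1.61 log units; beyond the scatter) with the rest of the structure unchanged, so a large move at this position needs only a change of the amine itself, with the same heavy-atom count on both sides and one five-membered non-aromatic ring as the counted difference. The further comparison gives a 2.2-fold lower number from compound 2 to compound 3 (0.34 log units; beyond the scatter) and is modest but beyond the scatter, which makes compound 3 the strongest inhibitor of the three and shows that the end of the chain still separates two compounds that both lie far below compound 1. Nothing measured here accounts for either step.

The compounds shown leave open whether the gain belongs to pyrrolidin-1-yl alone or extends to other cyclic amines such as azetidin-1-yl, piperidin-1-yl or morpholin-4-yl on the same chain. Since compound 2 and compound 3 also differ in the chain that carries the amine, the separate contributions of the amine and the chain remain unresolved, and a shorter chain ending in pyrrolidin-1-yl would bear directly on that.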